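Ester for methylamide on the acrylamide arm of compound 2

The source may report more compounds than this note shows. Statements on the series, on what has been measured and on what is new or still open speak of the compounds shown alone.

Series notes. The read-out throughout is an assay on a protein complex for inhibition of CDK8/Cyclin C (Homo sapiens), with a stated time of 1 h; on this read-out higher numbers stand for weaker inhibition and lower numbers for stronger inhibition. Compound 1 `CNC(=O)/C=C/c1ccncc1-c1ccc2[nH]ccc2c1` gives 51.9 nM. Compound 2 `CNC(=O)/C=C/c1ccncc1-c1ccc2c(cnn2C)c1` gives 86.7 nM. The two numbers lie within the usual scatter of one another, so no ordering of compound 1 and compound 2 is supported by the data in hand; compound 2 simply stands alongside compound 1 as one of two numbered entries. Compound 3 `CNC(=O)COc1ccncc1-c1ccc2ccccc2c1` gives "not determined" (no result reported) in this assay, so it adds nothing to the comparison and is set aside here.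

Compound 4 `CCOC(=O)/C=C/c1ccncc1-c1ccc2c(cnn2C)c1` has not yet been measured. Relative to compound 2 the change is ethoxy in place of methylamino on a carbonyl carbon. For the measured compounds named here, no measured pair in the set isolates this same change, so the size of the step rests on the structural change alone.

The exchange removes the one hydrogen-bond donor of the side chain and puts an acceptor in its place. In this assay compound 2 gives 86.7 nM, and the expectation is that compound 4 will come out weaker, with a step of a 4.6-fold higher number from compound 2 to compound 4 (0.66 log units; beyond the scatter) that is expected to exceed the scatter. The estimate for compound 4 is 400 nM, with a range from 120 nM to 1500 nM.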

Compound 4, half-maximal inhibitory concentration: 102 nM
The estimate for compound 4 lay 3.9-fold (0.59 log units) above the measured number; measured number below the stated range.
By their numbers in this assay, from the lowest: compounds 1, 2 and 4 (each within the scatter of the next).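

In this assay, for the compounds shown here, ethoxy in place of methylamino on a carbonyl carbon gives a 1.2-fold higher number from compound 2 to compound 4 (0.07 log units; within the scatter), the first step that varies this side chain, since compounds 1 and 2 both carry the methylcarbamoyl arm. In this pair, the arm tolerates losing the amide hydrogen and taking on the larger ethoxy group with no change that can be told from the scatter, so the hydrogen-bond donor of methylamino is not needed to keep compound 4 in the same range as compound 2. No independent measurement bears on why the two numbers stand so close together.

As far as these compounds go, this rests on a single pair on one core, so it remains open whether the same exchange would give a similarly small step on the core of compound 1. The pair also says nothing about how a carboxylic acid, a dimethylamino group or a longer chain such as butoxy on the same carbonyl carbon would read out, or whether the carbonyl itself can be replaced.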